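The compounds below may be only part of what the source reports. "The series", "measured", "known", "first", "only" and "open" are said of these compounds alone.

Compounds 1, 2 and 3 share one core and differ in the aryl group on a saturated ring carbon of the four-membered ring. In a functional assay on MCF7 cells (Homo sapiens) for antiproliferative activity, read by MTT assay, with stated times of 24 h and 72 h (on this read-out higher numbers stand for weaker inhibition and lower numbers for stronger inhibition), compound 1 (`COc1cccc([C@@H]2[C@H](Oc3ccccc3)C(=O)N2c2cc(OC)c(OC)c(OC)c2)c1`) gives 171000 nM as its reading. In this assay compound 2 (`COc1ccc([C@@H]2[C@H](Oc3ccccc3)C(=O)N2c2cc(OC)c(OC)c(OC)c2)cc1OC`) gives 26000 nM as its reading. Compound 3 (`COc1ccc([C@@H]2[C@H](Oc3ccccc3)C(=O)N2c2cc(OC)c(OC)c(OC)c2)cc1[N+](=O)[O-]`) gives 69000 nM and so stands second highest of the three numbers, with compound 1 higher and compound 2 lower.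

The next change leads to compound 4 (`COc1cc(N2C(=O)[C@@H](Oc3ccccc3)[C@H]2c2ccc(SC)cc2)cc(OC)c1OC`), with 4-(methylsulfanyl)phenyl in place of 4-methoxy-3-nitrophenyl on a saturated ring carbon. Three measured steps change this same aryl group, and all are modest. The first is a 6.6-fold lower number from compound 1 to compound 2 (0.82 log units; beyond the scatter) with methoxy in place of hydrogen on an aromatic carbon. The second is a 2.7-fold higher number from compound 2 to compound 3 (0.42 log units; beyond the scatter) with nitro in place of methoxy on an aromatic carbon. The third is a 2.5-fold lower number from compound 1 to compound 3 (0.39 log units; beyond the scatter) for the full exchange of aryl groups.

For the measured compounds named here, no measured compound carries a methylsulfanyl group, and the steps run in both directions, so the data give no firm direction. A modest change at most is expected in this assay, and the estimated step is a 1.4-fold lower number from compound 3 to compound 4 (0.14 log units; within the scatter) for now. For compound 4 the estimated value is 50000 nM with an expected range from 14000 nM to 170000 nM in this estimate.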

Compound 4, half-maximal inhibitory concentration: 7700 nM
The estimate for compound 4 lay 6.5-fold (0.81 log units) above the measured number, and the stated range ends above it.
By their numbers in this assay, from the lowest: compound 4; then compound 2; then compound 3; then compound 1.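

In this assay, the new aryl group gives a 9.0-fold lower number from compound 3 to compound 4 (0.95 log units; beyond the scatter), and it also beats the other two aryl groups, with a 3.4-fold lower number from compound 2 to compound 4 (0.53 log units; beyond the scatter) and a 22-fold lower number from compound 1 to compound 4 (1.35 log units; beyond the scatter). For the compounds shown here, this makes compound 4 the strongest inhibitor of the four, and the last of these steps is large, whereas every step among the earlier compounds was modest, so changing this aryl group can shift the reading further than those compounds suggested. Going by these compounds alone, the earlier aryl groups all carried oxygen-containing groups, and 4-(methylsulfanyl)phenyl shows that a group with sulfur and no oxygen is not only accepted on this saturated ring carbon but gives the lowest number so far; nothing at hand explains why this aryl group does better.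

Each of these steps exchanges a whole aryl group, so the compounds shown leave open whether the sulfur itself matters, and a simple 4-methoxyphenyl group would allow a closer comparison with compound 4. Going by these compounds, how far this gain extends also remains open, for instance with a longer chain on the sulfur, such as ethylsulfanyl, or with a dimethylamino group in its place.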